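Urea series: replacing the aryl group on the anilino nitrogen

The source may report more compounds than this note shows. Statements on the series, on what has been measured and on what is new or still open speak of the compounds shown alone.

Three compounds of the series have numbers in a functional assay on NCI-H520 cells (Homo sapiens) for inhibition, read by MTT assay, with a stated time of 48 h, tested at 10 uM; a higher number here means more inhibition at the concentration tested (going by the name of the read-out), a lower number less inhibition. Compound 1 `COc1cc(NC(=O)Nc2cc(Nc3cccc(C(C)(C)C)c3)ncn2)cc(OC)c1` gives 13.1% in this assay, the lowest of the three. Compound 2 `CC(C)(C)c1ccc(Nc2cc(NC(=O)Nc3c(Cl)cccc3Cl)ncn2)cc1` gives 22% in this assay, a number within the usual scatter of compound 1, so the two are not separable. Compound 3 `O=C(Nc1cc(Nc2ccc(F)c(Cl)c2)ncn1)Nc1c(Cl)cccc1Cl` gives 39.5% in this assay, a number beyond the scatter above compound 1; compound 3 is the only one of the three that stands clearly apart from compound 1. Among the compounds with values here, none of these pairs differs in a single place, so no step between measured compounds can be read off.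

Compound 4 `COc1cc(NC(=O)Nc2cc(Nc3ccc(OC)c(C)c3)ncn2)cc(OC)c1` has not been measured in this assay. It differs from compound 1 in one place: 4-methoxy-3-methylphenyl in place of 3-(tert-butyl)phenyl on a nitrogen on an aromatic ring. Within the data shown here, the data hold no single-point step that tests a change of this kind at this position. With nothing to point in either direction, the step from compound 1 to compound 4 is expected to be none beyond the scatter, a number 2.9 percentage points higher from compound 1 to compound 4 (within the scatter). Compound 4 is therefore estimated at 16% in this assay, with a range from 3% to 38%.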

Compound 4, a percentage reported as inhibition, at one concentration (the size of the read-out at that concentration, not a potency): 13.5%
Estimate against measurement, compound 4: 2.5 percentage points above; the measured number falls inside the stated range.
By their numbers in this assay, from the lowest: compounds 1, 4 and 2 (each within the scatter of the next); then compound 3.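

Within the data shown here, this is the first step that changes a single place. In this assay, 4-methoxy-3-methylphenyl in place of 3-(tert-butyl)phenyl on a nitrogen on an aromatic ring gives a number 0.4 percentage points higher from compound 1 to compound 4 (within the scatter). On the core of compound 1, this exchange of aryl groups therefore leaves the read-out unresolved from that of the starting compound, even though it removes the tert-butyl group and brings in a methoxy and a methyl group. No available measurement bears on why the step is this small.

Among these compounds, whether any group at this position can move the number on this core remains open, since a single step compares only two substituted phenyl groups. An aryl group carrying an amine or a carboxylic acid, or a longer alkyl chain on the same nitrogen, would test the position more widely.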